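Swapping the oxazole for cyclopropyl on the amide carbonyl

The compounds below may be only part of what the source reports. "The series", "measured", "known", "first", "only" and "open" are said of these compounds alone.

Measured so far:
- compound 1 `CCC(=O)N1CC[C@H](Oc2ncnc3c2nc(-c2cnc(C)nc2)n3CC)C1`: 1.2 L/kg
- compound 2 `CCn1c(-c2ccc(C(F)(F)F)nc2)nc2c(O[C@H]3CCN(C(=O)c4cocn4)C3)ncnc21`: 0.3 L/kg
- compound 3 `CCn1c(-c2cnc(C)nc2)nc2c(O[C@H]3CCN(C(=O)C4CCC4)C3)ncnc21`: 0.6 L/kg

In an ADME assay (Rattus norvegicus, strain Wistar Han) for pharmacokinetics (on this read-out lower numbers stand for narrower distribution and higher numbers for wider distribution into tissues), compound 2 gives the lowest of the three numbers. Compound 3 lies within the scatter of it, while compound 1 lies beyond the scatter with a higher number. Compound 4 `CCn1c(-c2ccc(C(F)(F)F)nc2)nc2c(O[C@H]3CCN(C(=O)C4CC4)C3)ncnc21` is the unmeasured compound, and it differs from compound 2 in one place: cyclopropyl in place of 1,3-oxazol-4-yl on a carbonyl carbon, the carbonyl carbon whose other neighbour is an amide-type nitrogen in a ring.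

Going by the values given here, only one measured step touches this same carbonyl carbon: a 2.0-fold lower number from compound 1 to compound 3 (0.30 log units; within the scatter). That step swapped one carbon-only group for another and stayed within the scatter, so it gives no sign that changes at this carbonyl carbon move this assay much. Among the compounds with values here, no measured step replaces a heteroaromatic ring here, so the effect of losing the 1,3-oxazol-4-yl ring itself is unknown. The expectation is therefore a step near zero or slightly upward, a 1.7-fold higher number from compound 2 to compound 4 (0.22 log units; within the scatter), which stays within the scatter. Compound 4 is estimated at 0.5 L/kg, with a range from 0.25 L/kg to 1 L/kg.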

Compound 4, volume of distribution: 0.7 L/kg
Estimate against measurement, compound 4: 1.4-fold (0.15 log units) below; the measured number falls inside the stated range.
By their numbers in this assay, from the lowest: compounds 2, 3, 4 and 1 (each within the scatter of the next, the first and the last beyond it).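

In this assay, going by these compounds alone, putting cyclopropyl in place of 1,3-oxazol-4-yl on the carbonyl carbon gives a 2.3-fold higher number from compound 2 to compound 4 (0.37 log units; beyond the scatter), the first step at this carbonyl carbon that lies beyond the scatter, though only modestly. The earlier step here, a 2.0-fold lower number from compound 1 to compound 3 (0.30 log units; within the scatter), stayed within the scatter and exchanged one carbon-only group for another, whereas this one removes an aromatic ring holding nitrogen and oxygen, so the position can move this read-out after all. Nothing measured on these groups accounts for the shift.

The compounds shown cannot separate the effect of losing the 1,3-oxazol-4-yl ring from that of gaining cyclopropyl. Going by these compounds, how a phenyl ring or a dimethylamino group on this carbonyl carbon would read remains open, as does whether the same swap gives a similar step on the core of compound 1.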